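The compounds below may be only part of what the source reports. "The series", "measured", "known", "first", "only" and "open" are said of these compounds alone.

The series shares one core, seen in compound 1 `COC(=O)C1=C(C)N=C(C)/C(=C(\O)OC)C1c1cccc(OC(=O)c2ccccc2)c1`, compound 2 `COC(=O)C1=C(C)N=C(C)/C(=C(\O)OC)C1c1cccc(Cl)c1Cl` and compound 3 `COC(=O)C1=C(C)N=C(C)/C(=C(\O)OC)C1c1cc(C)ccc1C`, and varies only in the aryl group on a saturated ring carbon. In a functional assay (muscle tissue) with Cavia porcellus as the target (a higher number here means that more compound is needed for the effect, a lower number that less compound is needed), compound 1 gives 6310 nM, compound 2 gives 19.1 nM and compound 3 gives 100 nM. Compound 3 stands second highest of the three numbers; its nearest neighbour is compound 2 and the furthest is compound 1. Among the measured compounds shown here, the single measured step is a 5.2-fold higher number from compound 2 to compound 3 (0.72 log units; beyond the scatter). Compound 4 `COC(=O)C1=C(C)N=C(C)/C(=C(\O)OC)C1c1cccc(Br)c1` is the next candidate: 3-bromophenyl in place of 2,5-dimethylphenyl on a saturated ring carbon. For the measured compounds named here, no measured step introduces a bromine, so only the dichlorophenyl-to-dimethylphenyl step bears on it, and that step ran towards a higher number on leaving the chlorine-bearing ring. Going by the values given here, a lower number is expected for compound 4 than for compound 3 because compound 2 gives 19.1 nM, the lowest number so far, with a halogen-bearing ring. The estimate in this assay is a step of a 3.3-fold lower number from compound 3 to compound 4 (0.52 log units; beyond the scatter), a lower number beyond the scatter but smaller than the measured step. Compound 4 is expected to give 30 nM, within 8 nM to 120 nM.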

Compound 4, half-maximal effective concentration: 1.29 nM
Estimate against measurement, compound 4: 23-fold (1.37 log units) above, and the stated range ends above it.
By their numbers in this assay, from the lowest: compound 4; then compound 2; then compound 3; then compound 1.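

In this assay, a single bromine on the aryl ring gives the lowest number of the set, with a 78-fold lower number from compound 3 to compound 4 (1.89 log units; beyond the scatter) and a 15-fold lower number from compound 2 to compound 4 (1.17 log units; beyond the scatter) showing that neither the two methyl groups nor the two chlorines are needed for a low number. Compound 1 also carries one substituent on its aryl ring, so one substituent alone does not guarantee a low number: a 4900-fold lower number from compound 1 to compound 4 (3.69 log units; beyond the scatter) is the largest step in the series and comes from the exchange of benzoyloxy for bromo on an aromatic carbon. No measurement at hand explains these steps.

Going by these compounds, whether bromine itself matters stays open, and 3-chlorophenyl, 3-methylphenyl or 3-nitrophenyl would help to settle this. On these data alone, the methoxycarbonyl group stays the same throughout, so the effect of an ethyl or longer alkyl ester in this assay also remains open.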